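This account rests on a few compounds, and the source may have more. Where it says the series, first, only, none or still open, it means among the compounds named here.

Compound 1 `CSc1cccc(-c2cc(NC(=O)C(Cl)Cl)cc(-c3cccc(SC)c3)c2)c1` carries two methylsulfanylphenyl arms on its central ring, and in a functional assay on A549 cells (Homo sapiens) for cytotoxicity, read by MTT assay, with a stated time of 68 h (on this read-out higher numbers stand for weaker inhibition and lower numbers for stronger inhibition), compound 1 gives 15900 nM. Compound 2 `O=C(Nc1cccc(-c2nccs2)c1)C(Cl)Cl` keeps the dichloroacetamide but bears a single five-membered heteroaromatic ring on the aniline. In this assay compound 2 reaches only the limit of the assay, > 50000 nM, so no number is known for it (the limit of > 50000 nM in this assay, at which 1 of the 2 values shown sits). Compound 3 `O=C(Nc1cccc(-c2cccs2)c1)C(Cl)Cl` differs from compound 2 in one place: thiophen-2-yl in place of 1,3-thiazol-2-yl on an aromatic carbon. Among the measured compounds shown here, no measured pair shows this change, so its size in this assay is untested; given that compound 2 stands at the limit of > 50000 nM in this assay, at which 1 of the 2 values shown sits, and that one small heteroaromatic ring is swapped for a near relative, the step of a number no higher from compound 2 to compound 3 (the limit leaves the size open) is expected to stay within the scatter. Compound 3 is therefore estimated to give 50000 nM in this assay, between 20000 nM and 120000 nM, and quite possibly will again be reported only as a limit.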

Compound 3, half-maximal inhibitory concentration: 47600 nM
Beside the measured number, compound 3's estimate is 1.1-fold (0.02 log units) above it; the measured number falls inside the stated range.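

With thiophen-2-yl on this aromatic carbon, compound 3 gives 47600 nM in this assay, so this position now carries a measured number for a single five-membered aromatic ring. Compound 2 is recorded only as a limit, > 50000 nM. The change of 1,3-thiazol-2-yl to thiophen-2-yl can therefore be read only as an at least 1.0-fold lower number from compound 2 to compound 3 (0.02 log units; that floor lies within the scatter), which shows no effect beyond the scatter but does not fix the true size of the step: the limit of > 50000 nM in this assay, at which 1 of the 3 values shown sits.

On these data alone, what a furan-2-yl ring, a pyridin-3-yl ring or an aminomethyl group would give on the same aromatic carbon stays open. Also open, as far as these compounds go, is how much the dichloroacetamide itself contributes, for instance against a plain acetamide on the same aniline.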